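The compounds below may be only part of what the source reports. "The series", "measured", "known", "first", "only" and "open" are said of these compounds alone.

Compound 1, `Ic1ccc(Cn2cc(CCCOc3cccc4cccnc34)nn2)cc1`: in a functional assay on NCI/ADR-RES cells (Homo sapiens) for inhibition, read by sulforhodamine B assay, with a stated time of 48 h (on this read-out lower numbers stand for stronger inhibition of growth and higher numbers for weaker inhibition of growth), compound 1 gives > 250 ug/mL, which is a limit of the assay and not a number.
Compound 2, `Brc1ccc(Cn2cc(CCCOc3cccc4cccnc34)nn2)cc1`: in this assay compound 2 gives 25.8 ug/mL.
Compound 3, `Clc1cc(Cl)c(Cn2cc(CCCOc3cccc4cccnc34)nn2)c(Cl)c1`: in this assay compound 3 gives 2.8 ug/mL.

Compound 1 therefore stands only at a limit in this assay, the weakest point among the three measured compounds, as the limit of > 250 ug/mL in this assay, at which 1 of the 3 values shown sits, records. Both measured steps that leave compound 1 move toward stronger growth inhibition: an at least 9.6-fold lower number from compound 1 to compound 2 (0.98 log units; beyond the scatter) and an at least 89-fold lower number from compound 1 to compound 3 (1.95 log units; beyond the scatter). The third step, a 9.2-fold lower number from compound 2 to compound 3 (0.96 log units; beyond the scatter), lies between the two halogenated benzyl groups and does not touch compound 1 directly.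

Compound 4, `c1cncc(CCCn2cc(CCCOc3cccc4cccnc34)nn2)c1`, is not yet measured in this assay. It differs from compound 1 by 2-(pyridin-3-yl)ethyl in place of 4-iodophenyl on a saturated chain carbon bound to an aromatic nitrogen. Going by the values given here, no measured step removes the halogen altogether or introduces a ring nitrogen, so the two steps from compound 1 give only a direction, not a size. Since every change made so far at this position gave a lower number than compound 1, compound 4 is expected to show an at least 2.0-fold lower number from compound 1 to compound 4 (0.31 log units; beyond the scatter), though the number may still rest at the limit. Compound 4 is estimated at 120 ug/mL in this assay, with a range from 25 ug/mL to 250 ug/mL.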

Compound 4, concentration for 50% growth inhibition: 12.5 ug/mL
For compound 4 the middle estimate is 9.6-fold (0.98 log units) above the measured one; measured number outside the range, below it.
By their numbers in this assay, from the lowest: compound 3; then compound 4; then compound 2. At a limit, above all of these: compound 1.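

The result shows that this position, on a saturated chain carbon bound to an aromatic nitrogen, needs no halogen for growth inhibition: in this assay, 2-(pyridin-3-yl)ethyl in place of 4-iodophenyl gives an at least 20-fold lower number from compound 1 to compound 4 (1.30 log units; beyond the scatter). The size of that step is open on one side, as compound 1 stands at a limit and not at a number: the limit of > 250 ug/mL in this assay, at which 1 of the 4 values shown sits. Among the halogenated compounds, the new group does not simply rank last, with a 2.1-fold lower number from compound 2 to compound 4 (0.31 log units; beyond the scatter), although 2,4,6-trichlorophenyl still gives the stronger inhibition, with a 4.5-fold higher number from compound 3 to compound 4 (0.65 log units; beyond the scatter).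

The change to compound 4 swaps 4-iodobenzyl for 3-(pyridin-3-yl)propyl, so the ring nitrogen, the longer chain and the loss of iodine all arrive together, and a 3-phenylpropyl group or a pyridin-3-ylmethyl group at this place would be needed to pull them apart. Also open, going by these compounds, is how an amine or a carboxylic acid on the same chain would read in this assay.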